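The source may hold more compounds than are shown below. What is called first, only, known or untested is meant among the compounds shown, and "the series" means these compounds.

Measured compounds:
compound 1 `CC1=CC[C@H](C(C)C)c2cc(C)c(OC(=O)c3ccc([N+](=O)[O-])cc3)cc21` — 36.7%
compound 2 `Cc1cc2c(C(C)C)ccc(C)c2cc1OC(=O)c1ccc(C(F)(F)F)cc1` — 100%
compound 3 `Cc1cc2c(C(C)C)ccc(C)c2cc1OC(=O)c1ccc([N+](=O)[O-])cc1` — 100%

In a functional assay on PC-3 cells (Homo sapiens) for antiproliferative activity, read by sulforhodamine B assay, with a stated time of 48 h, tested at 50 uM (on this read-out lower numbers stand for less inhibition and higher numbers for more inhibition at the one concentration tested (going by the name of the read-out)), compound 1 gives 36.7%, the lowest of the three numbers. Compound 2 and compound 3 share a core unlike that of compound 1, and the gap from compound 1 to each of them is beyond the scatter. Compound 2 gives 100%, and compound 3 gives 100%.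

Compound 4 `COc1ccc(C(=O)Oc2cc3c(cc2C)[C@@H](C(C)C)CC=C3C)cc1` is compound 1 with one change: methoxy in place of nitro on an aromatic carbon. Within the data shown here, the only measured step that touches the same position is the one from compound 2 to compound 3, nitro in place of trifluoromethyl, which gave no change at the digits printed from compound 2 to compound 3 (within the scatter); both partners there sit at the top of the read-out, so the step cannot reveal how much a change at that position matters. Among the measured compounds shown here, no measured pair swaps nitro for methoxy, and none does so on the core of compound 1.

With so little to go on, a step near zero in this assay is expected, and compound 4 is estimated at 35%, within 10% to 70%. That would mean a step of a number 1.7 percentage points lower from compound 1 to compound 4 (within the scatter), which is expected to stay within the scatter.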

Compound 4, a percentage reported as inhibition, at one concentration (the size of the read-out at that concentration, not a potency): 60.6%
For compound 4 the middle estimate is 25.6 percentage points below the measured one; measured number inside the range.
By their numbers in this assay, from the lowest: compound 1; then compound 4; then compounds 2 and 3 (each within the scatter of the next).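

In this assay the swap of nitro for methoxy on the core of compound 1 gives a number 23.9 percentage points higher from compound 1 to compound 4 (beyond the scatter) and so shows that the group at this place can change the result. The earlier step between compound 2 and compound 3 could not show this, since both sit at the top of the read-out, where a real difference would stay hidden. Nothing available here explains why the number rises with this change.

The compounds shown leave open how an amine or a carboxylic acid at this place would read on the core of compound 1, and whether trifluoromethyl there would read like nitro or like methoxy. They also leave open whether this step carries over to the core shared by compound 2 and compound 3, where the read-out has no room left to rise.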